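Swapping an Ester for Trifluoromethyl: Expected Half-Life

The source may hold more compounds than are shown below. What is called first, only, known or untested is meant among the compounds shown, and "the series" means these compounds.

Measured so far:
compound 1 `Cc1cc(CCC#N)cc(C)c1Oc1cc(Nc2ccc(C#N)cc2)c(N)cc1C(F)(F)F` gives 0.928 h
compound 2 `COC(=O)c1cc(N)c(Nc2ccc(C#N)cc2)cc1Oc1c(C)cc(CCC#N)cc1C` gives 3.1 h
compound 3 `COC(=O)c1cc(N)c(Nc2ccc(C#N)cc2)cc1Oc1c(C)cc(/C=C/C#N)cc1C` gives 4.72 h

These three compounds were tested in an in vitro ADME assay on microsomes from liver (Homo sapiens) for metabolic stability, tested at 1 uM; a higher number here means that the compound lasts longer, a lower number that the compound disappears faster. Compound 4 `Cc1cc(/C=C/C#N)cc(C)c1Oc1cc(Nc2ccc(C#N)cc2)c(N)cc1C(F)(F)F` has not been measured there yet. Compound 4 is made from compound 3 by one change: trifluoromethyl in place of methoxycarbonyl on an aromatic carbon. The same change has already been made once among the measured compounds and gave a 3.3-fold lower number from compound 2 to compound 1 (0.52 log units; beyond the scatter). Compound 3 and compound 4 share a core that differs from the core of compound 2 and compound 1 by 2-cyanoethenyl in place of 2-cyanoethyl on an aromatic carbon; that core change gave a 1.5-fold higher number from compound 2 to compound 3 (0.18 log units; within the scatter). Among the compounds with values here, for compound 4, the step of a 3.4-fold lower number from compound 3 to compound 4 (0.53 log units; beyond the scatter) is expected to be about as large as the earlier one, because the step of a 3.3-fold lower number from compound 2 to compound 1 (0.52 log units; beyond the scatter) is the only measured example of this change. Compound 4 is therefore estimated to give 1.4 h, likely between 0.7 h and 2.9 h.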

Compound 4, half-life: 0.75 h
Compound 4: the middle estimate sits 1.9-fold (0.27 log units) above what was measured, and the stated range covers the measured number.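

Placing trifluoromethyl where methoxycarbonyl stood in this assay gives a 6.3-fold lower number from compound 3 to compound 4 (0.80 log units; beyond the scatter) and so lowers the number on the second core too, by an amount that does not differ measurably between the two cores: the same change on two cores in this assay, a 3.3-fold lower number (0.52 log units; beyond the scatter) from compound 2 to compound 1 and a 6.3-fold lower number (0.80 log units; beyond the scatter) from compound 3 to compound 4, 1.9-fold (0.28 log units) apart, within the scatter of two such steps. Placing 2-cyanoethenyl where 2-cyanoethyl stood gives a 1.2-fold lower number from compound 1 to compound 4 (0.09 log units; within the scatter) and also reads alike on both cores: the same change on two cores in this assay, a 1.5-fold higher number (0.18 log units; within the scatter) from compound 2 to compound 3 and a 1.2-fold lower number (0.09 log units; within the scatter) from compound 1 to compound 4, 1.9-fold (0.28 log units) apart, within the scatter of two such steps. These two cores differ only in that chain, so this does not show that either change would carry over to a core that differs more.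

From the compounds shown here alone, whether a carboxylic acid or an amide in place of methoxycarbonyl would give a longer or shorter half-life stays open. Also open, going by these compounds, is how a longer chain in place of 2-cyanoethenyl would behave alongside trifluoromethyl.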